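A few compounds are considered here, and "the series" means these few. Any claim that something is new, unique, unknown or untested is made for them only; others in the source may bear on it.

Measured compounds:
compound 1, `CN(C(=S)SCc1ccc(C(=O)Nc2ccccc2N)cc1)c1cccnc1`, gives 87.7%
compound 2, `Nc1ccccc1NC(=O)c1ccc(CSC(=S)N2CCN(c3ccccc3F)CC2)cc1`, gives 79.5%

Both numbers come from a functional assay on A-375 cells (Homo sapiens) for antiproliferative activity, read by CCK-8 assay, with a stated time of 72 h, tested at 8 uM; a lower number here means a weaker effect, a higher number a stronger effect of the compound at the concentration tested. Compound 1 holds the higher of the two numbers, yet its nearest neighbour, compound 2, sits within the usual scatter of it, so the two cannot be placed in any order of activity. Within the data shown here, no step between two measured compounds that differ in a single place is available here, so nothing about the size of a single change has been seen directly.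

The unmeasured compound 3, `Nc1ccccc1NC(=O)c1ccc(CSC(=S)N2CCCC2)cc1`, is related to compound 1 by one change: pyrrolidin-1-yl in place of methyl(pyridin-3-yl)amino on a thiocarbonyl carbon. The group that leaves is larger than the group that enters, and the entering ring is non-aromatic, with no hydrogen-bond acceptor. Compound 2 shows that a different, also non-aromatic, nitrogen ring on the same thiocarbonyl carbon still gives a high reading in this assay, so a collapse is not expected; a moderate fall, beyond the scatter, is the more likely outcome. The step from compound 1 to compound 3 is therefore estimated at a number 19.7 percentage points lower from compound 1 to compound 3 (beyond the scatter). Compound 3 is expected to give about 68%, within a range from 45% to 88%.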

Compound 3, a percentage reported as inhibition, at one concentration (the size of the read-out at that concentration, not a potency): 89.5%
For compound 3 the middle estimate is 21.5 percentage points below the measured one; measured number above the stated range.
By their numbers in this assay, from the lowest: compounds 2, 1 and 3 (each within the scatter of the next).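

In this assay, exchanging methyl(pyridin-3-yl)amino for pyrrolidin-1-yl on the thiocarbonyl carbon gives a number 1.8 percentage points higher from compound 1 to compound 3 (within the scatter), the first direct view of a single change at this position. It shows that, at the concentration tested, a high reading at this position does not depend on the six-membered aromatic ring or its hydrogen-bond acceptor, as a five-membered non-aromatic ring with fewer heavy atoms serves equally well within the scatter. No available evidence explains why the reading is retained after this change.

The compounds shown leave open whether an open-chain amine such as dimethylamino, or a ring with a further hetero atom such as morpholin-4-yl, would also retain the reading on the thiocarbonyl carbon. Going by these compounds, a reading at one concentration is also not a potency, so it remains open whether compound 1 and compound 3 would separate at lower concentrations.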